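The source may hold more compounds than are shown below. What is called first, only, known or untested is meant among the compounds shown, and "the series" means these compounds.

Measured compounds in a functional assay on NCI-H1975 cells (Homo sapiens) for antiproliferative activity, read by MTT assay, with a stated time of 72 h; on this read-out higher numbers stand for weaker inhibition and lower numbers for stronger inhibition:
- compound 1 `COc1cc2ncnc(Nc3ccc(F)c(Cl)c3)c2cc1OCCCCC(=O)Nc1ccc(S(N)(=O)=O)cc1`: 35600 nM
- compound 2 `COc1cc2ncnc(Nc3cccc(F)c3)c2cc1OCCCCC(=O)Nc1ccc(S(N)(=O)=O)cc1`: > 40000 nM
- compound 3 `COc1cc2ncnc(Nc3ccc(Br)cc3)c2cc1OCCCCC(=O)Nc1ccc(S(N)(=O)=O)cc1`: 23300 nM

Compound 2 reaches only a limit of this assay, (the limit of > 40000 nM in this assay, at which 1 of the 3 values shown sits), so no number stands for it. Compound 3 holds the lowest of the two numbers shown, yet its nearest neighbour is compound 1 and that gap, a 1.5-fold lower number from compound 1 to compound 3 (0.18 log units; within the scatter), is within the scatter; compound 3 cannot be called more potent than compound 1. The step of an at least 1.7-fold lower number from compound 2 to compound 3 (0.23 log units; that floor lies within the scatter) is a floor and also within the scatter, as is an at least 1.1-fold higher number from compound 1 to compound 2 (0.05 log units; that floor lies within the scatter).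

Compound 4 `COc1ccc(Nc2ncnc3cc(OC)c(OCCCCC(=O)Nc4ccc(S(N)(=O)=O)cc4)cc23)cc1OC` differs from compound 3 at the aniline part of the shared core: 3,4-dimethoxyphenyl in place of 4-bromophenyl on a nitrogen on an aromatic ring. All measured steps concern exchanges of halogenated phenyl groups on that nitrogen, and none moved the number beyond the scatter. No measured step introduces methoxy groups, so the direction of the change is not supported by a shown step; the expectation is therefore no change beyond the scatter, with a wider range toward weaker inhibition given the limit reached by compound 2.

Compound 4 is estimated at 30000 nM, range 12000 nM to 60000 nM. The step expected, a 1.3-fold higher number from compound 3 to compound 4 (0.11 log units; within the scatter), is within the scatter.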

Compound 4, half-maximal inhibitory concentration: 9230 nM
Compound 4: the middle estimate sits 3.3-fold (0.51 log units) above what was measured; the whole stated range lies above it.
By their numbers in this assay, from the lowest: compound 4; then compounds 3 and 1 (each within the scatter of the next). At a limit, above all of these: compound 2.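

In this assay, the aniline nitrogen gives its first steps beyond the scatter, with 3,4-dimethoxyphenyl as the entering group against each halogenated phenyl group (a 2.5-fold lower number from compound 3 to compound 4 (0.40 log units; beyond the scatter)) and (a 3.9-fold lower number from compound 1 to compound 4 (0.59 log units; beyond the scatter)) and (an at least 4.3-fold lower number from compound 2 to compound 4 (0.63 log units; beyond the scatter)). Compound 4 therefore holds the lowest number of the set, and this position responds to a non-halogen phenyl group in a way the exchanges among halogenated phenyl groups did not show. The step from compound 2 is only a floor because compound 2 sits at a limit: the limit of > 40000 nM in this assay, at which 1 of the 4 values shown sits.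

Going by these compounds, whether both methoxy groups are needed stays open, since a phenyl group carrying a single methoxy group, or an ethoxy group in their place, would separate their shares. Also open, on these data alone, is whether the step holds with a shorter chain or with a carboxylic acid in place of the sulfonamide.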